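Removing a Butoxy Group: What to Expect for Compound 4

This account rests on a few compounds, and the source may have more. Where it says the series, first, only, none or still open, it means among the compounds named here.

Of the compounds shown here, three have so far been tested in an assay on cells for inhibition of S-adenosylmethionine decarboxylase proenzyme (Homo sapiens), read by mass spectrometry, at pH 7.2; on this read-out higher numbers stand for weaker inhibition and lower numbers for stronger inhibition.

Compound 1, `Cc1cc(Nc2cc(Cl)cc(S(F)(F)(F)(F)F)c2)nc(N)n1`, gives > 180000 nM.
Compound 2, `CCCCOc1cc(Br)cc(Nc2cc(C)nc(N)n2)c1`, gives > 180000 nM.
Compound 3, `Cc1cc(C)cc(Nc2cc(C)nc(N)n2)c1`, gives > 180000 nM.

Each of these three values is a limit of the assay and not a number. Compound 2 therefore stands at that limit, and so do the two other compounds, as shown by the limit of > 180000 nM in this assay, at which 3 of the 3 values shown sit. Nothing in these results sets one compound apart from another.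

Compound 4, `Cc1cc(Nc2cccc(Br)c2)nc(N)n1`, differs from compound 2 in one place: hydrogen in place of butoxy on an aromatic carbon. For the measured compounds named here, no measured pair shows the effect of such a change here, so its size cannot be read from the data, and the step from compound 2 to compound 4 is expected to be a step that the limit leaves unreadable from compound 2 to compound 4, no shift beyond the scatter of repeated measurements. Compound 4 is accordingly expected to fall at 250000 nM, within a range from 60000 nM to 1000000 nM, with a strong chance that the assay again reports only a limit.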

Compound 4, half-maximal inhibitory concentration: > 180000 nM
Compound 4 was reported as a limit; the forecaster's own chance of this, stated with the estimate: 80%; the middle value lies beyond the limit too.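

The step from compound 2 to compound 4 cannot be sized, because neither compound gives a number: the limit of > 180000 nM in this assay, at which 4 of the 4 values shown sit.

The compounds shown leave open whether removing butoxy, or changing any other group on the shared core, alters inhibition of the enzyme at all.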